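The source may report more compounds than this note shows. Statements on the series, on what has been measured and on what is new or still open speak of the compounds shown alone.

Working notes on the ester-linked amide series. Compound 1 `Cc1cc2c(cc1C(=O)c1ccc(C(=O)OCCCOC(=O)c3ccc(C(=O)Nc4ccc5c(c4)C(C)(C)CCC5(C)C)cc3)cc1)C(C)(C)CCC2(C)C` gives 49100 nM in a functional assay on K562 cells (Homo sapiens) for inhibition, read by MTT assay, with a stated time of 48 h; on this read-out lower numbers stand for stronger inhibition and higher numbers for weaker inhibition. Compound 2 `C=C(c1ccc(C(=O)OCCOC(=O)c2ccc(C(=O)Nc3ccc4c(c3)C(C)(C)CCC4(C)C)cc2)cc1)c1cc2c(cc1C)C(C)(C)CCC2(C)C` gives 504000 nM in this assay. Compound 3 `CCCC(CCC)C(=O)OCCCCOC(=O)c1ccc(C(=O)Nc2ccc3c(c2)C(C)(C)CCC3(C)C)cc1` is reported in this assay only as a limit, > 1000000 nM, so no number is known for it. On the values shown, compound 3 therefore stands at the weak end, at the limit of > 1000000 nM in this assay, at which 1 of the 3 values shown sits, while compound 1 and compound 2 carry measured numbers. Compound 4 `CCCC(=O)OCCOC(=O)c1ccc(C(=O)Nc2ccc3c(c2)C(C)(C)CCC3(C)C)cc1` is the next member and is not yet measured in this assay. It differs from compound 3 in one place: (propylcarbonyl)oxy in place of 2-(((1-propylbutyl)carbonyl)oxy)ethyl on a saturated chain carbon, two bonds along the chain from an oxygen next to a carbonyl group. The chain entering is shorter than the chain leaving, the remainder of the molecule being unchanged. For the measured compounds named here, no step between two measured compounds is available to size a change of this kind. The expectation is that compound 4 stays close to compound 3, with the estimated step of a number no higher from compound 3 to compound 4 (the limit leaves the size open) being none beyond the scatter. Compound 4 is estimated at 1000000 nM, within 300000 nM to 3000000 nM, and the assay may again report only a limit rather than a number.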

Compound 4, half-maximal inhibitory concentration: 18600 nM
Compound 4: the middle estimate sits 54-fold (1.73 log units) above what was measured; measured number outside the range, below it.
By their numbers in this assay, from the lowest: compound 4; then compound 1; then compound 2. At a limit, above all of these: compound 3.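

In this assay, (propylcarbonyl)oxy in place of 2-(((1-propylbutyl)carbonyl)oxy)ethyl on a saturated chain carbon, two bonds along the chain from an oxygen next to a carbonyl group, gives an at least 53-fold lower number from compound 3 to compound 4 (1.73 log units; beyond the scatter). For the compounds shown here, this is the first sized step, and it shows that a change at this place alone, with the rest of the molecule unchanged, can move the number far beyond the scatter. The true size of the step stays open because compound 3 is reported only as a limit: the limit of > 1000000 nM in this assay, at which 1 of the 4 values shown sits.

A single step cannot separate the shorter chain from the loss of the 1-propylbutyl branch, and steps involving compound 1 or compound 2 cannot be read. As far as these compounds go, whether an unbranched longer chain, an amine or a carboxylic acid at this place would keep the lower number remains open.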